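Cyanosulfanyl in place of bromo on a limit compound

This account rests on a few compounds, and the source may have more. Where it says the series, first, only, none or still open, it means among the compounds named here.

Measured in a functional assay on L1210 cells (Mus musculus) for cytotoxicity, with a stated time of 48 h; on this read-out lower numbers stand for stronger inhibition and higher numbers for weaker inhibition:
Compound 1, `Clc1ccc(Cc2nn3c(Br)c(-c4ccc(Cl)cc4)nc3s2)cc1`: > 250000 nM
Compound 2, `Clc1ccc(Cc2nn3c(Br)c(-c4ccc(Cl)cc4Cl)nc3s2)cc1`: 31000 nM
Compound 3, `Clc1ccc(Cc2nn3c(Br)c(-c4ccccc4)nc3s2)cc1`: > 250000 nM

The value of compound 1 in this assay is a limit, not a number. The same holds for compound 3, whose value is also a limit. Only compound 2 gives a number. The measured steps all concern the aryl group on the shared core: an at least 8.0-fold lower number from compound 1 to compound 2 (0.90 log units; beyond the scatter), an at least 8.0-fold higher number from compound 2 to compound 3 (0.90 log units; beyond the scatter), and a step that the two limits leave unreadable from compound 1 to compound 3. Two of the three values sit at the limit (the limit of > 250000 nM in this assay, at which 2 of the 3 values shown sit), so compound 1 stands where most of this small set stands.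

Compound 4, `N#CSc1c(-c2ccc(Cl)cc2)nc2sc(Cc3ccc(Cl)cc3)nn12`, differs from compound 1 by cyanosulfanyl in place of bromo on an aromatic carbon. Within the data shown here, none of the measured steps changes the bromo; each alters the aryl group instead, and the bromo is kept in compound 1, compound 2 and compound 3 alike. Among the measured compounds shown here, no step therefore bears directly on the change to compound 4, and the expectation rests on compound 1 alone, whose value > 250000 nM is a limit. Compound 4 is expected to remain near that limit, with the step of an at least 1.2-fold lower number from compound 1 to compound 4 (0.09 log units; that floor lies within the scatter) not readable beyond the scatter. The estimate for compound 4 in this assay is 200000 nM, within 40000 nM to 600000 nM.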

Compound 4, half-maximal inhibitory concentration: 49000 nM
For compound 4 the middle estimate is 4.1-fold (0.61 log units) above the measured one; measured number inside the range.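

In this assay, among these compounds, the earlier steps all altered the aryl group and kept the bromo, so they said nothing about this aromatic carbon of the shared core. Here the 4-chlorophenyl group stays in place, and cyanosulfanyl in place of bromo brings an at least 5.1-fold lower number from compound 1 to compound 4 (0.70 log units; beyond the scatter). This shows that the read-out of compound 1 can be moved from this position as well as from the aryl group, but the value of compound 1 is a limit, so the step gives only a floor and not a full size: the limit of > 250000 nM in this assay, at which 2 of the 4 values shown sit.

The compounds shown do not separate the sulfur from the nitrile within the cyanosulfanyl group, and they leave open how a methylsulfanyl group, a nitrile attached directly to the ring carbon or an amine would behave at this carbon. They also leave open whether cyanosulfanyl and the 2,4-dichlorophenyl group of compound 2 would act together on one molecule, or whether each lowers the number only on its own.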